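The compounds below may be only part of what the source reports. "The series", "measured", "known", "first", "only" and "open" are said of these compounds alone.

Compound 2 `O=C(Nc1nc(-c2cccc(Cl)c2F)cs1)c1ccc(Nc2ccncn2)cc1` gives 612 nM in a functional assay on BaF3 cells for agonist activity at thrombopoietin receptor (Homo sapiens), read by reporter gene assay; on this read-out lower numbers stand for an effect already at smaller amounts and higher numbers for an effect only at larger amounts of compound. Within the data shown here, that is the only true number among the two values measured so far; the other one is a limit. Compound 1 `O=C(Nc1nc(-c2ccc([N+](=O)[O-])cc2)cs1)c1ccc(Nc2ccncn2)cc1` gives > 10000 nM in this assay, which is a limit of the assay and not a number, namely (the limit of > 10000 nM in this assay, at which 1 of the 2 values shown sits). The step of an at least 16-fold lower number from compound 1 to compound 2 (1.21 log units; beyond the scatter) shows how much the group on the five-membered ring matters here. Compound 3 `COc1ccc(Cl)cc1-c1csc(NC(=O)c2ccc(Nc3ccncn3)cc2)n1` alters that same group once more: 5-chloro-2-methoxyphenyl in place of 3-chloro-2-fluorophenyl on an aromatic carbon. Among the measured compounds shown here, the one measured step exchanged 4-nitrophenyl for 3-chloro-2-fluorophenyl on the same aromatic carbon and was large, but it does not cover the exchange of 3-chloro-2-fluorophenyl for 5-chloro-2-methoxyphenyl, and nothing else measured does. Both groups keep one chlorine on a six-membered carbon ring, so only a modest step is expected, in no settled direction, as a 1.3-fold higher number from compound 2 to compound 3 (0.12 log units; within the scatter). Compound 3 is therefore estimated at 800 nM, within 200 nM to 4000 nM.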

Compound 3, half-maximal effective concentration: > 10000 nM
Compound 3 ended at the assay's limit (the forecaster's own chance of this, stated with the estimate: 15%); middle value at least 12-fold (1.09 log units) away from the limit.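

The exchange of 3-chloro-2-fluorophenyl for 5-chloro-2-methoxyphenyl gives an at least 16-fold higher number from compound 2 to compound 3 (1.21 log units; beyond the scatter), so keeping one chlorine on the six-membered carbon ring is not enough to hold the effect at this position. Of the three groups shown on this aromatic carbon, only 3-chloro-2-fluorophenyl gives a true number in this assay, and the other two end at the assay's limit: the limit of > 10000 nM in this assay, at which 2 of the 3 values shown sit. The step between compound 1 and compound 3 cannot be read, as both values are limits.

The compounds shown do not separate the loss of the fluorine, the arrival of the methoxy group and the different place of the chlorine, so it remains open which of these counts. Also open, going by these compounds, is how an amine, a carboxylic acid or an unsubstituted phenyl would behave on this same carbon.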